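Swapping cyclopentylamino for hexyloxy on a shared core

The compounds below may be only part of what the source reports. "The series", "measured", "known", "first", "only" and "open" are said of these compounds alone.

Two analogues built on one core have been tested in an ADME assay on BCBL1 cells (Homo sapiens) for cytotoxicity, with a stated time of 7 days; a higher number here means that more compound is tolerated, a lower number that less compound is tolerated. Compound 1, `COCCOc1nc(N)nc2c1ncn2/C=C1/CC1(CO)CO`, carries a 2-methoxyethoxy group; in this assay compound 1 reaches only a limit, > 20000 nM. Within the data shown here, compound 2, `Nc1nc(NC2CCCC2)c2ncn(/C=C3/CC3(CO)CO)c2n1`, carries cyclopentylamino instead, and in this assay compound 2 gives 71700 nM, the only actual number among the two values available. The step that the limit leaves unreadable from compound 1 to compound 2 cannot be sized because of the limit of > 20000 nM in this assay, at which 1 of the 2 values shown sits. Compound 3, `CCCCCCOc1nc(N)nc2c1ncn2/C=C1/CC1(CO)CO`, is not yet measured; it differs from compound 2 by hexyloxy in place of cyclopentylamino on an aromatic carbon. Among the measured compounds shown here, only one measured step exists and it is unreadable, so it bears on this change only loosely; what remains is that compound 1, with its 2-methoxyethoxy group, sat at the limit, while compound 2 with cyclopentylamino gave a readable number. On that basis the step of a 1.8-fold lower number from compound 2 to compound 3 (0.25 log units; within the scatter) is expected to be small or to run toward the limit, with no confident direction beyond the scatter. Compound 3 is therefore estimated at 40000 nM, within 15000 nM to 120000 nM.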

Compound 3, half-maximal cytotoxic concentration: > 20000 nM
Compound 3 was reported as a limit; the forecaster's own chance of this, stated with the estimate: 50%; the middle value is on the limit's open side.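

In this assay, among these compounds, compound 3 reaches only a limit of > 20000 nM and so no step linking compound 3 with compound 1 or compound 2 can be read: the limit of > 20000 nM in this assay, at which 2 of the 3 values shown sit. The compounds shown leave open how far compound 1 and compound 3 actually lie from compound 2, and whether hexyloxy and 2-methoxyethoxy differ at all in this read-out.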